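Thiophene for Phenyl on Two Nucleoside Cores

The source may report more compounds than this note shows. Statements on the series, on what has been measured and on what is new or still open speak of the compounds shown alone.

Compound 1 `Cc1nc(N)c2c(-c3ccccc3)cn([C@@H]3O[C@H](CO)[C@@H](O)[C@H]3O)c2n1` gives > 20000 nM in a functional assay on HL-60 cells (Homo sapiens) for antiproliferative activity, read by XTT assay, with a stated time of 72 h (on this read-out lower numbers stand for stronger inhibition and higher numbers for weaker inhibition), which is a limit of the assay rather than a number.
Compound 2 `Cc1nc(N)c2c(-c3ccsc3)cn([C@@H]3O[C@H](CO)[C@@H](O)[C@H]3O)c2n1` gives > 20000 nM in this assay, again a limit.
Compound 3 `Nc1nc2c(c(-c3ccccc3)cn2[C@@H]2O[C@H](CO)[C@@H](O)[C@H]2O)c(=O)[nH]1` gives > 20000 nM in this assay, also a limit.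

The three measured compounds share a sugar-bearing bicyclic core and carry either a phenyl or a thiophen-3-yl group. Compound 1 and compound 2 differ by one change, (thiophen-3-yl in place of phenyl on an aromatic carbon), and the step is a step that the two limits leave unreadable from compound 1 to compound 2. Compound 3 carries a different core from compound 1; the difference between the two cores is not broken down here.

Compound 4 `Nc1nc2c(c(-c3ccsc3)cn2[C@@H]2O[C@H](CO)[C@@H](O)[C@H]2O)c(=O)[nH]1` has not yet been measured in this assay. It differs from compound 3 by thiophen-3-yl in place of phenyl on an aromatic carbon, the same change that separates compound 1 from compound 2, made at the same place on the ring.

What can be expected for compound 4 rests on (the limit of > 20000 nM in this assay, at which 3 of the 3 values shown sit). The earlier step from phenyl to thiophen-3-yl left compound 2 at the limit, and compound 3 sits at the limit as well. Compound 4 is therefore expected to sit at or beyond the same limit, with an estimated value of 30000 nM, between 15000 nM and 100000 nM. The step from compound 3 to compound 4 is accordingly expected to be a step that the limit leaves unreadable from compound 3 to compound 4, most likely reported only as a limit.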

Compound 4, half-maximal inhibitory concentration: > 20000 nM
Compound 4: a limit, no number; the forecaster's own chance of this, stated with the estimate: 90%; the middle value is on the limit's open side.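

In this assay compound 4 gives > 20000 nM, which is a limit and not a number. Compound 3 also stands at a limit, so no step can be read from compound 3 to compound 4, and none from compound 1 to compound 2. The compounds shown leave open whether thiophen-3-yl in place of phenyl alters the read-out on either core, for all they show in common is this: the limit of > 20000 nM in this assay, at which 4 of the 4 values shown sit.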